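The source may hold more compounds than are shown below. What is called first, only, known or untested is meant among the compounds shown, and "the series" means these compounds.

Compound 1 `CCOC(=O)CCO/N=C(/c1ccc(OC)c(OC)c1OC)c1cccc2ccccc12` carries an ester-bearing chain on the shared core. In a functional assay on MDA-MB-231 cells (Homo sapiens) for inhibition, read by sulforhodamine B assay, with a stated time of 48 h (a higher number here means a weaker inhibitor, a lower number a stronger inhibitor), compound 1 gives 15200 nM, the highest of the two numbers recorded here; the nearest is compound 2 `COc1ccc(C(c2ccc(OC(C)CN(C)C)cc2)c2cccc3ccccc23)c(OC)c1OC`, which gives 4340 nM, a gap that lies beyond the usual scatter. Compound 3 `COc1ccc(C(O)(Cc2ccc(C)cc2)c2cccc3ccccc23)c(OC)c1OC` gives only a limit of the assay, > 20000 nM. Compound 4 `CCOC(=O)CO/N=C(/c1ccc(OC)c(OC)c1OC)c1cccc2ccccc12` differs from compound 1 in one place: ethoxycarbonyl in place of (ethoxycarbonyl)methyl on a saturated chain carbon bound to an oxygen on an unsaturated carbon, leaving the rest untouched. Going by the values given here, no pair of measured compounds shows what such a shortening does, so the step is expected to be a 1.0-fold lower number from compound 1 to compound 4 (0.01 log units; within the scatter), not beyond the scatter in either direction. Compound 4 is therefore estimated at 15000 nM, with a range from 6000 nM to 40000 nM.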

Compound 4, half-maximal inhibitory concentration: 16400 nM
Compound 4: middle estimate off by 1.1-fold (0.04 log units), on the low side, within the range that was stated.
By their numbers in this assay, from the lowest: compound 2; then compounds 1 and 4 (each within the scatter of the next). At a limit, above all of these: compound 3.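

Going from 2-(ethoxycarbonyl)ethoxy to (ethoxycarbonyl)methoxy brings a 1.1-fold higher number from compound 1 to compound 4 (0.03 log units; within the scatter) in this assay. This is the only pair shown that differs in one place, and at this position the shorter chain cannot be told apart from the longer one. Compound 3 stands at a limit of the assay, so little room for reading a further loss remains above this pair: the limit of > 20000 nM in this assay, at which 1 of the 4 values shown sits.

On these data alone, whether a carboxylic acid in place of the ethyl ester, an amine, or a longer chain at this position would move the number stays open.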